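This account rests on a few compounds, and the source may have more. Where it says the series, first, only, none or still open, it means among the compounds named here.

Measured in a functional assay on MDA-MB-231 cells (Homo sapiens) for cytotoxicity, read by MTT assay, with a stated time of 24 h; a higher number here means a weaker inhibitor, a lower number a stronger inhibitor:
- Compound 1 `O=C1/C(=C/c2ccccc2F)CN(Cc2cn(Cc3ccccc3F)nn2)C/C1=C\c1ccccc1F`: 16000 nM
- Compound 2 `COc1ccc(/C=C2\CN(C(=S)SCc3cn(Cc4cccc(Cl)c4)nn3)C/C(=C\c3ccc(OC)cc3)C2=O)cc1`: 32000 nM
- Compound 3 `O=C1/C(=C/c2ccccc2F)CN(C(=S)SCc2cn(Cc3ccc(F)cc3)nn2)C/C1=C\c1ccccc1F`: 58800 nM

Compound 1, at 16000 nM, cannot be separated within the scatter from compound 2, at 32000 nM. Compound 3, at 58800 nM, carries a higher number than compound 1, a gap beyond the scatter, although it does not separate from compound 2. Compound 1 therefore sits at the stronger end of this small set, in company with compound 2.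

Compound 4 `O=C1/C(=C/c2ccccc2F)CN(Cc2cn(Cc3ccc(F)cc3)nn2)C/C1=C\c1ccccc1F` keeps the atoms of compound 1 but joins them differently: 4-fluorophenyl in place of 2-fluorophenyl on a saturated chain carbon bound to an aromatic nitrogen. It has 4-fluorophenyl in place of 2-fluorophenyl on a saturated chain carbon bound to an aromatic nitrogen. Going by the values given here, no measured pair isolates this change, so the data offer no direct guide to its size, and no step beyond the scatter is expected in this assay. The starting point is compound 1 at 16000 nM. The estimated step of a 1.3-fold higher number from compound 1 to compound 4 (0.10 log units; within the scatter) stays small. Compound 4 is expected at 20000 nM, with an estimated range from 8000 nM to 50000 nM.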

Compound 4, half-maximal inhibitory concentration: 10000 nM
Compound 4: the middle estimate sits 2.0-fold (0.30 log units) above what was measured; low and high end bracket the measured number.
By their numbers in this assay, from the lowest: compounds 4, 1, 2 and 3 (each within the scatter of the next, the first and the last beyond it).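

Going by these compounds alone, this is the first pair in the set that differs in one place: in this assay, 4-fluorophenyl in place of 2-fluorophenyl on a saturated chain carbon bound to an aromatic nitrogen gives a 1.6-fold lower number from compound 1 to compound 4 (0.20 log units; within the scatter) and so stays within the scatter. At this position on the shared core, then, the two fluorophenyl groups cannot be told apart in this assay, and the change neither gains nor loses anything the measurements can resolve. Nothing available bears on why the two compounds read alike.

As far as these compounds go, whether a nitrile or a carboxylic acid on that phenyl ring would give a step beyond the scatter remains open. Compound 3 also carries 4-fluorophenyl but has no 2-fluorophenyl partner here, so whether the same change behaves alike in that compound cannot be read.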